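From Methoxyphenyl to Fluorophenyl on the Ring Nitrogen

A few compounds are considered here, and "the series" means these few. Any claim that something is new, unique, unknown or untested is made for them only; others in the source may bear on it.

Measured so far:
compound 1, `CCCc1nc(-c2ccccc2)c(CNCCN2CCN(c3ccccc3Cl)CC2)o1`, 4370 nM
compound 2, `CCCc1nc(-c2ccccc2)c(CNCCN2CCN(c3ccc(OC)cc3)CC2)o1`, 9200 nM

Going by the values given here, in an assay on HEK293 cells for inhibition of Voltage-dependent T-type calcium channel subunit alpha-1G (Homo sapiens), read by patch clamp (on this read-out higher numbers stand for weaker inhibition and lower numbers for stronger inhibition), compound 2 gives 9200 nM, the highest of the two numbers; its only neighbour is compound 1, and the step of a 2.1-fold higher number from compound 1 to compound 2 (0.32 log units; beyond the scatter) separates them. Compound 3, `CCCc1nc(-c2ccccc2)c(CNCCN2CCN(c3cccc(F)c3)CC2)o1`, differs from compound 2 by 3-fluorophenyl in place of 4-methoxyphenyl on an amine nitrogen in a ring. Among the compounds with values here, the one measured step bears on this change only loosely: it shows that a halogen-bearing phenyl on that nitrogen gave a somewhat lower number than the methoxyphenyl, but the halogen and its position are not the same as in compound 3, so that step cannot be carried over directly. A modest move back toward the number of compound 1, or none beyond the scatter, is expected. For compound 3 the estimate in this assay is 5500 nM, from 2200 nM to 14000 nM, a step of a 1.7-fold lower number from compound 2 to compound 3 (0.22 log units; within the scatter).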

Compound 3, half-maximal inhibitory concentration: 3350 nM
Estimate against measurement, compound 3: 1.6-fold (0.22 log units) above; low and high end bracket the measured number.
By their numbers in this assay, from the lowest: compounds 3 and 1 (each within the scatter of the next); then compound 2.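

In this assay, 3-fluorophenyl in place of 4-methoxyphenyl on the ring nitrogen gives a 2.7-fold lower number from compound 2 to compound 3 (0.44 log units; beyond the scatter) and so adds a second halogen-bearing phenyl that has a lower number than the 4-methoxyphenyl compound. The exchange of the two halogen-bearing groups gives a 1.3-fold lower number from compound 1 to compound 3 (0.12 log units; within the scatter) and does not separate 2-chlorophenyl from 3-fluorophenyl on this read-out. No measurement is available that explains the difference between these groups.

Each step changes the kind of substituent and its place on the phenyl together, leaving the contribution of each unresolved. As far as these compounds go, it also remains open how an unsubstituted phenyl, or a phenyl carrying a trifluoromethyl or a nitrile, would compare on this ring nitrogen.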